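The source may report more compounds than this note shows. Statements on the series, on what has been measured and on what is new or still open speak of the compounds shown alone.

Compound 2, with the structure `COc1ccc(-c2cnc(NC(=O)C3CCCCC3)n2C)cc1`, is tested in a toxicity assay on THP-1 cells (Homo sapiens) for inhibition (on this read-out lower numbers stand for higher toxicity in this test and higher numbers for lower toxicity in this test), and gives only a limit, > 100000 nM. Compound 1, with the structure `Cn1c(-c2cccc(Cl)c2)cnc1NC(=O)c1ccc(F)cc1`, also reaches only a limit in this assay: > 50000 nM. Compound 3, with the structure `COc1ccc(-c2ccnc(NC(=O)c3ccc(F)cc3)c2)cc1`, likewise stands at a limit in this assay, > 100000 nM. So compound 2 sits at the limit of > 100000 nM in this assay, at which 2 of the 3 values shown sit, and compound 1 sits at the limit of > 50000 nM in this assay, at which 1 of the 3 values shown sits. Since none of the three compounds yields a number, no measured step between any pair of them can be drawn, and compound 2 stands neither higher nor lower than its two companions on what is shown.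

Compound 4, with the structure `COc1ccc(-c2cnc(NC(=O)c3ccn[nH]3)n2C)cc1`, has not yet been measured. It differs from compound 2 in one place: 1H-pyrazol-5-yl in place of cyclohexyl on a carbonyl carbon. With every measured value a limit, the expected step is a number no higher from compound 2 to compound 4 (the limit leaves the size open), that is, none beyond the usual scatter. For compound 4 the estimate in this assay is 100000 nM, with a range from 30000 nM to 300000 nM, and most likely another limit.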

Compound 4, half-maximal cytotoxic concentration: > 100000 nM
Compound 4 ended at the assay's limit; the forecaster's own chance of this, stated with the estimate: 80%; the middle value sits exactly at the limit.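

Compound 2 and compound 4 both stand at a limit in this assay, so no step can be read between them. The compounds shown leave open whether 1H-pyrazol-5-yl in place of cyclohexyl on a carbonyl carbon changes this read-out at all.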